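The compounds below may be only part of what the source reports. "The series", "measured", "known", "first", "only" and "open" are said of these compounds alone.

Compound 2 `Cc1ccc2[nH]c(C(=O)N[C@H]3CN(S(=O)(=O)c4ccccc4)C[C@@H]3C(=O)N[C@H]3CCCNC3)cc2c1` stands lowest of the two numbers in an ADME assay on cells (Hepatocyte, Rattus norvegicus) for metabolic stability (a lower number here means slower removal, a higher number faster removal of the compound), where compound 2 gives 7 uL/min. Within the data shown here, its nearest neighbour is compound 1 `Cc1ccc2[nH]c(C(=O)N[C@H]3CN(S(=O)(=O)c4ccccc4)C[C@@H]3C(=O)N[C@H]3CCCN(C)C3)cc2c1`, which in this assay gives 23 uL/min; the one measured step runs a 3.3-fold lower number from compound 1 to compound 2 (0.52 log units; beyond the scatter). Compound 3 `Cc1csc(C(=O)N[C@H]2CN(S(=O)(=O)c3ccccc3)C[C@@H]2C(=O)N[C@H]2CCCNC2)n1` has not yet been measured in this assay. It differs from compound 2 in one place: 4-methyl-1,3-thiazol-2-yl in place of 5-methyl-1H-indol-2-yl on a carbonyl carbon. Among the measured compounds shown here, no measured step bears on this change, since the only step in hand, a 3.3-fold lower number from compound 1 to compound 2 (0.52 log units; beyond the scatter), concerns the amine nitrogen in a ring and not the group on the carbonyl carbon. With nothing to point either way, no step beyond the scatter is expected. Compound 3 is therefore estimated at 7 uL/min in this assay, with a range from 2.5 uL/min to 20 uL/min. The step that this estimate means is expected to be no change at the digits printed from compound 2 to compound 3 (within the scatter).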

Compound 3, intrinsic clearance in a liver preparation (reported as CLH), per the amount of preparation that the assay uses: < 1 uL/min
Compound 3 ended at the assay's limit; the forecaster's own chance of this, stated with the estimate: 15%; middle value at least 7.0-fold (0.84 log units) away from the limit.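

Putting 4-methyl-1,3-thiazol-2-yl in place of 5-methyl-1H-indol-2-yl on a carbonyl carbon gives an at least 7.0-fold lower number from compound 2 to compound 3 (0.84 log units; beyond the scatter) in this assay. The group on the carbonyl carbon is therefore a second place, besides the amine nitrogen in a ring, where a single change moves the number beyond the scatter. In this assay compound 3 gives < 1 uL/min, which is a limit of the assay and not a number.

On these data alone, the full size of the step stays open because compound 3 sits at that limit: the limit of < 1 uL/min in this assay, at which 1 of the 3 values shown sits. Also open, as far as these compounds go, is whether a plain phenyl group or a 1,3-thiazol-2-yl group without its methyl on the carbonyl carbon would give a similar result, and whether a methyl on the amine nitrogen would raise the number with the 4-methyl-1,3-thiazol-2-yl group in place.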